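Methoxy in Place of Fluoro: What Compound 3 May Give

A few compounds are considered here, and "the series" means these few. Any claim that something is new, unique, unknown or untested is made for them only; others in the source may bear on it.

Compound 1 `O=C(CCC(=O)c1cccs1)NCCCO` and compound 2 `O=C1CCC2(c3ccc(F)cc3)OCCCN12` were both tested in a functional assay on the whole organism with Mus musculus as the target; on this read-out lower numbers stand for an effect already at smaller amounts and higher numbers for an effect only at larger amounts of compound. For compound 1 the result is only a limit of the assay, > 300 mg/kg, not a number. Among the measured compounds shown here, compound 2 gives 50 mg/kg, the only plain value in this assay so far. Compound 3 `COc1ccc(C23CCC(=O)N2CCCO3)cc1` differs from compound 2 by methoxy in place of fluoro on an aromatic carbon. For the measured compounds named here, no measured pair shows how such a change acts here, so the expected step from compound 2 to compound 3 is a 1.2-fold higher number from compound 2 to compound 3 (0.08 log units; within the scatter), within the usual scatter. Compound 3 is therefore estimated at 60 mg/kg, between 25 mg/kg and 150 mg/kg.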

Compound 3, dose for half-maximal effect: 139 mg/kg
Compound 3: middle estimate off by 2.3-fold (0.36 log units), on the low side; low and high end bracket the measured number.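

In this assay, among the compounds shown here, methoxy in place of fluoro on an aromatic carbon, para to a large group, gives a 2.8-fold higher number from compound 2 to compound 3 (0.44 log units; beyond the scatter) and so provides the first measured step at this position. The position is therefore not indifferent to this change, and of these two groups, fluoro carries the lower number. This single pair cannot show why.

As far as these compounds go, whether a chloro group, a hydroxyl or an amine at the same place would give a lower number than fluoro stays open. Much higher numbers could also meet a limit of the assay: the limit of > 300 mg/kg in this assay, at which 1 of the 3 values shown sits.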